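Piperazine nitrogen substituent and human microsomal stability

This account rests on a few compounds, and the source may have more. Where it says the series, first, only, none or still open, it means among the compounds named here.

Measured so far:
compound 1 `CN(C[C@H]1Cc2c(cccc2N2CCN3CCC[C@H]3C2)CN1)[C@H]1CCCc2cccnc21` gives 36.6%
compound 2 `CCN(C[C@H]1Cc2c(cccc2N2CCNCC2)CN1)[C@H]1CCCc2cccnc21` gives 79.1%
compound 3 `CN(C[C@H]1Cc2c(cccc2N2CCN(c3cccc(C(F)(F)F)c3)CC2)CN1)[C@H]1CCCc2cccnc21` gives 90.3%

In an ADME assay on microsomes from liver (Homo sapiens) for metabolic stability, read by LC-MS, with a stated time of 10 min (on this read-out higher numbers stand for a more stable compound and lower numbers for a less stable compound), compound 3 holds the highest of the three numbers. Compound 2, at 79.1%, lies nearest, and that gap is beyond the scatter. Compound 1, at 36.6%, lies furthest, again beyond the scatter. Among the compounds with values here, no two measured compounds differ in a single place, so no measured step is available for any one change.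

Compound 4 `CN(C[C@H]1Cc2c(cccc2N2CCNCC2)CN1)[C@H]1CCCc2cccnc21` has not yet been run in this assay. Against compound 3 the change is hydrogen in place of 3-(trifluoromethyl)phenyl on an amine nitrogen in a ring. Among the measured compounds, compound 2 is the closest structural relative of compound 4, carrying hydrogen on the same amine nitrogen in a ring.

A downward step beyond the scatter is expected, of moderate rather than large size, as the expected step of a number 16.3 percentage points lower from compound 3 to compound 4 (beyond the scatter) in this assay. Compound 4 is expected to give about 74%, within 55% to 90%, because compound 2 gives 79.1% in this assay.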

Compound 4, percent of the compound remaining: 99.7%
Compound 4: middle estimate off by 25.7 percentage points, on the low side, outside the stated range (above it).
By their numbers in this assay, from the lowest: compound 1; then compound 2; then compounds 3 and 4 (each within the scatter of the next).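

In this assay, hydrogen in place of 3-(trifluoromethyl)phenyl on this ring amine nitrogen gives a number 9.4 percentage points higher from compound 3 to compound 4 (within the scatter), so the readout does not separate these two substituents. Hydrogen in place of methyl on a saturated chain carbon bound to an amine nitrogen gives a number 20.6 percentage points higher from compound 2 to compound 4 (beyond the scatter), and the change of the group on the aromatic carbon gives a number 63.1 percentage points higher from compound 1 to compound 4 (beyond the scatter), so among these pairs the steps beyond the scatter lie at those two places, not at this nitrogen. Nothing in hand accounts for any of these steps.

Open, from the compounds shown here alone, is whether an acetyl group or a longer alkyl chain on this nitrogen would read apart from hydrogen in this assay. Also open, going by these compounds, is whether an unsubstituted phenyl there would read with 3-(trifluoromethyl)phenyl.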